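The source may hold more compounds than are shown below. What is called first, only, known or untested is meant among the compounds shown, and "the series" means these compounds.

In a functional assay on MGC-803 cells (Homo sapiens) for cytotoxicity, read by MTT assay, with a stated time of 48 h (on this read-out lower numbers stand for stronger inhibition and higher numbers for weaker inhibition), compound 1 (`CCN(CC)CC(=O)N1N=C(C)CC1c1ccccc1O`) gives 39800 nM while compound 2 (`CC1=NN(C(=O)CN2CCN(C(=O)OC(C)(C)C)CC2)C(c2ccccc2O)C1`) gives 17600 nM and compound 3 (`CCN(CC)CC(=O)N1N=C(C)CC1c1ccccc1OC(C)=O`) gives 29500 nM in the same test. Compound 3 thus has the middle number of the three, although its value lies within the usual scatter of both others. Compound 4 (`CC(=O)Oc1ccccc1C1CC(C)=NN1C(=O)CCl`) keeps the acetyl group of compound 3 but differs from it in one place (chloro in place of diethylamino on a saturated chain carbon bound to a carbonyl carbon) with chloro in place of diethylamino on a saturated chain carbon bound to a carbonyl carbon. For the measured compounds named here, the only measured step between compounds differing in one place is a 1.3-fold lower number from compound 1 to compound 3 (0.13 log units; within the scatter) and it concerns the acetyl group, not this change. Going by the values given here, no measured step replaces diethylamino with chloro, so the size of this step remains uncertain. Compound 2 at 17600 nM does carry a different group in place of diethylamino, and its number stays within the scatter of that of compound 3, so no step beyond the scatter is expected here. The expected change is a 1.5-fold lower number from compound 3 to compound 4 (0.17 log units; within the scatter) and so is not expected to exceed the scatter. For compound 4 the estimated value is 20000 nM with an expected range from 6000 nM to 60000 nM in this assay for now.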

Compound 4, half-maximal inhibitory concentration: 3010 nM
Estimate against measurement, compound 4: 6.6-fold (0.82 log units) above; the measured number lies below the stated range.
By their numbers in this assay, from the lowest: compound 4; then compounds 2, 3 and 1 (each within the scatter of the next, the first and the last beyond it).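

In this assay, putting chloro in place of diethylamino on a saturated chain carbon bound to a carbonyl carbon gives a 9.8-fold lower number from compound 3 to compound 4 (0.99 log units; beyond the scatter) and marks this position as one where a single change moves the number beyond the scatter. For the compounds shown here, the only earlier step, at the oxygen on the aromatic ring, was a 1.3-fold lower number from compound 1 to compound 3 (0.13 log units; within the scatter) and gave no sign that any place on these compounds could respond so strongly, so the side chain on the carbonyl now stands out as the more sensitive of the two places compared in this way. No measurement shown here bears on what lies behind this step.

The compounds shown leave open whether the step follows from the arrival of chloro or from the departure of diethylamino, and a compound with bromo, methyl or a morpholine on the same chain carbon would help to separate the two. As far as these compounds go, it also remains open whether the acetyl group still makes as little difference with chloro on the chain, which a partner of compound 4 carrying a free hydroxyl in place of the acetyl ester would test.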